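Pyridinylmethyl Swap on a Hydantoin Hydroxamate

The compounds below may be only part of what the source reports. "The series", "measured", "known", "first", "only" and "open" are said of these compounds alone.

Measured compounds:
Compound 1 `O=C(NO)c1ccc(CN2C(=O)CN(Cc3ccc(Cl)cc3)C2=O)cc1`: 994 nM
Compound 2 `O=C(NO)c1ccc(CN2C(=O)C(Cc3ccccc3)N(Cc3ccccn3)C2=O)cc1`: 7830 nM

In an assay on isolated protein for inhibition of histone deacetylase 8 (Homo sapiens), read by fluorescence, with stated times of 10 min and 1 h (on this read-out higher numbers stand for weaker inhibition and lower numbers for stronger inhibition), compound 2 gives 7830 nM, the higher of the two numbers; compound 1, with 994 nM, lies lower by a gap beyond the usual scatter. Compound 3 `O=C(NO)c1ccc(CN2C(=O)C(Cc3ccccc3)N(Cc3cccnc3)C2=O)cc1` carries the change (pyridin-3-yl in place of pyridin-2-yl on a saturated chain carbon bound to an amide-type nitrogen in a ring). For the measured compounds named here, no step of this kind has been measured here, so the expectation for this assay is no change beyond the scatter, perhaps a slight easing. The expected step from compound 2 to compound 3 is a 1.3-fold lower number from compound 2 to compound 3 (0.12 log units; within the scatter). Compound 3 is estimated at 6000 nM, within 2500 nM to 15000 nM.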

Compound 3, half-maximal inhibitory concentration: 3440 nM
For compound 3 the middle estimate is 1.7-fold (0.24 log units) above the measured one, and the stated range covers the measured number.
By their numbers in this assay, from the lowest: compound 1; then compound 3; then compound 2.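

In this assay, pyridin-3-yl in place of pyridin-2-yl gives a 2.3-fold lower number from compound 2 to compound 3 (0.36 log units; beyond the scatter), a modest step beyond the scatter. This shows that the position responds to which pyridine isomer it carries, even though the two groups have the same atoms. Nothing available here explains the step. From the compounds shown here alone, whether pyridin-4-yl or a plain phenyl ring would extend the trend remains open. Compound 1 differs from compound 2 and compound 3 in more than one place, so the separate contributions of its 4-chlorobenzyl group and unsubstituted ring carbon also remain unresolved.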